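Ester to amide on a branched dienoate chain

This account rests on a few compounds, and the source may have more. Where it says the series, first, only, none or still open, it means among the compounds named here.

Measured compounds:
compound 1 `CC#CCOC(=O)/C=C(C)/C=C/CC(C)CCCC(C)C`, 6.4
compound 2 `CCOC(=O)/C=C(C)/C=C/CC(C)CCC(O)C(C)C`, 4.65

In a physicochemical assay for lipophilicity (a lower number here means a more polar compound, a higher number a more lipophilic compound), compound 1 gives 6.4, the higher of the two numbers. Compound 2, which carries a hydroxyl on its chain and an ethyl ester, gives 4.65 in this assay, lower than compound 1 by a gap beyond the usual scatter. Going by the values given here, no two measured compounds differ in a single place, so no single step has been measured yet.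

Compound 3 `C=CCNC(=O)/C=C(C)/C=C/CC(C)CCCC(C)C` is not yet measured. It differs from compound 1 in one place: allylamino in place of (but-2-yn-1-yl)oxy on a carbonyl carbon. A group with one hydrogen-bond acceptor leaves and a group with one hydrogen-bond donor enters on the carbonyl carbon, and one heavy atom fewer remains. On the numbers shown, the step is expected to lower this assay, beyond the scatter, by a number 1.00 log units lower from compound 1 to compound 3 (beyond the scatter). Compound 3 is therefore expected to give about 5.4, in the range 4.7 to 6.1.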

Compound 3, partition coefficient: 5.23
The estimate for compound 3 lay 0.17 log units above the measured number, and the stated range covers the measured number.
By their numbers in this assay, from the lowest: compound 2; then compound 3; then compound 1.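

Placing allylamino in place of (but-2-yn-1-yl)oxy on a carbonyl carbon gives, in this assay, a number 1.17 log units lower from compound 1 to compound 3 (beyond the scatter), so the group on this carbonyl carbon alone, with the rest of compound 1 unchanged, moves the reading by a large step. The change turns an ester into an amide, exchanges a triple bond for a double bond, and exchanges a hydrogen-bond acceptor for a hydrogen-bond donor, all in one step. No separate measurement bears on which of these differences accounts for the step.

The compounds shown leave open how the step divides between the oxygen-to-nitrogen exchange and the triple-to-double bond exchange, which a but-2-yn-1-ylamino or an allyloxy group on the same carbonyl carbon would separate. They also leave open whether a step of this size holds on the hydroxyl-bearing chain of compound 2.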